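The source may hold more compounds than are shown below. What is called first, only, known or untested is meant among the compounds shown, and "the series" means these compounds.

In an assay on CHO cells for displacement of a labelled ligand from adenosine receptor A3 (Homo sapiens), read by scintillation counting, with a stated time of 120 min, tested at 1 uM (on this read-out lower numbers stand for less inhibition and higher numbers for more inhibition at the one concentration tested (going by the name of the read-out)), compound 3 `C=C(C)COc1ccc(-c2c(C#N)c(N)nc(SCC(N)=O)c2C#N)cc1` gives 4%, the smallest of the three numbers at hand, though both others lie within the scatter of it: compound 1 `N#Cc1c(N)nc(SCC(N)=O)c(C#N)c1-c1ccc(OCC2CC2)cc1` gives 8% and compound 2 `CC(C)COc1ccc(-c2c(C#N)c(N)nc(SCC(N)=O)c2C#N)cc1` gives 9%. Compound 4 `N#Cc1c(N)nc(SCC(N)=O)c(C#N)c1-c1ccc(OCC2CCC2)cc1` is not yet measured and differs from compound 3 by cyclobutyl in place of 1-methylethenyl on a saturated chain carbon bound to an oxygen on an aromatic ring. Every measured step changes the same place, and none moves beyond the scatter: a number 1 percentage points higher from compound 1 to compound 2 (within the scatter), a number 4 percentage points lower from compound 1 to compound 3 (within the scatter) and a number 5 percentage points lower from compound 2 to compound 3 (within the scatter). Because a number 1 percentage points higher from compound 1 to compound 2 (within the scatter) and a number 5 percentage points lower from compound 2 to compound 3 (within the scatter) stay within the scatter, compound 4 is expected to show no step beyond it either, the estimated change being a number 3 percentage points higher from compound 3 to compound 4 (within the scatter). For compound 4 the estimate is 7%, expected to fall between 0% and 18%.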

Compound 4, a percentage reported as inhibition, at one concentration (the size of the read-out at that concentration, not a potency): 1%
The estimate for compound 4 lay 6 percentage points above the measured number; the range from low to high includes it.
By their numbers in this assay, from the lowest: compounds 4, 3, 1 and 2 (each within the scatter of the next).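

In this assay cyclobutyl in place of 1-methylethenyl gives a number 3 percentage points lower from compound 3 to compound 4 (within the scatter) and in place of isopropyl gives a number 8 percentage points lower from compound 2 to compound 4 (within the scatter) while in place of cyclopropyl it gives a number 7 percentage points lower from compound 1 to compound 4 (within the scatter) at the same place, on a saturated chain carbon bound to an oxygen on an aromatic ring. A four-membered ring of carbon therefore joins the groups at this place without any step leaving the scatter. Nothing at hand accounts for these numbers. On these data alone, whether an amine, a carboxylic acid or a longer chain at this place would give a step beyond the scatter remains open.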